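From isopropylcarbonyl to methyl on a sulfur

This account rests on a few compounds, and the source may have more. Where it says the series, first, only, none or still open, it means among the compounds named here.

Compound 1 (`CC(C)C(=O)SCCCCCCNC(=O)c1cc(-c2ccncc2)n[nH]1`) has been tested in a functional assay on A549 cells (Homo sapiens) for inhibition, read by MTT assay, with a stated time of 96 h (a lower number here means a stronger inhibitor of growth, a higher number a weaker inhibitor of growth), where compound 1 gives 16800 nM. Among the compounds with values here, this is the only exact number so far. Its close relative, compound 2 (`CCC(=O)SCCCCCCNC(=O)c1cc(-c2ccncc2)n[nH]1`), gives > 50000 nM, which is a limit of the assay and not a number.

The next molecule, compound 3 (`CSCCCCCCNC(=O)c1cc(-c2ccncc2)n[nH]1`), differs from compound 1 at the same end of the structure: methyl in place of isopropylcarbonyl on a sulfur. The whole group with its carbonyl is gone in compound 3. Within the data shown here, only one measured step bears on this change. That step, an at least 2.9-fold higher number from compound 1 to compound 2 (0.47 log units; beyond the scatter), put hydrogen in place of a single methyl within the group, and it lies beyond the scatter, towards weaker growth inhibition. Compound 3 loses more of the group, so a step in the same direction is expected, though one step is a thin guide. The expected change is a 2.7-fold higher number from compound 1 to compound 3 (0.43 log units; beyond the scatter) in this assay. For compound 3 the estimated value is 45000 nM, with an expected range from 18000 nM to 120000 nM.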

Compound 3, concentration for 50% growth inhibition: > 50000 nM
Compound 3 was reported as a limit (the forecaster's own chance of this, stated with the estimate: 60%); at least 1.1-fold (0.04 log units) between middle value and limit.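

Putting methyl in place of isopropylcarbonyl on the sulfur gives an at least 2.9-fold higher number from compound 1 to compound 3 (0.47 log units; beyond the scatter) in this assay. The earlier step changed only a single methyl within the group, whereas this one shows that growth inhibition also weakens beyond the scatter when the whole group, carbonyl included, is gone, so among the compounds shown only compound 1, with its isopropylcarbonyl, gives an exact number. The step between compound 2 and compound 3 cannot be read, and neither compound can be ranked against the other, because each is reported only as a limit and not as a number: the limit of > 50000 nM in this assay, at which 2 of the 3 values shown sit.

The compounds shown do not separate the loss of the carbonyl from the loss of the carbon atoms around it, and they do not tell how far compound 2 and compound 3 actually fall from compound 1. They also leave open what a larger group on the sulfur would do, such as benzoyl or a longer branched acyl chain, and what a plain hydrogen there, giving a free thiol, or an amine in place of the sulfur would do.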